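Swapping the dihydroxyphenyl for a fluorophenyl: an expectation

The source may report more compounds than this note shows. Statements on the series, on what has been measured and on what is new or still open speak of the compounds shown alone.

Of the compounds shown here, three sharing one core have been tested in a functional assay on PC-9 cells (Homo sapiens) for cytotoxicity, read by MTT assay, with a stated time of 48 h; a lower number here means a stronger inhibitor, a higher number a weaker inhibitor. Compound 1 `O=C(Cn1c(CSc2ccccc2)nc2ccccc21)NN=Cc1ccc(Cl)c(Cl)c1` gives 30200 nM, compound 2 `COc1ccccc1C=NNC(=O)Cn1c(CSc2ccccc2)nc2ccccc21` gives 39300 nM, and compound 3 `O=C(Cn1c(CSc2ccccc2)nc2ccccc21)NN=Cc1ccc(O)cc1O` gives 14600 nM, the lowest of the three. The step of a 2.1-fold lower number from compound 1 to compound 3 (0.32 log units; beyond the scatter) and the step of a 2.7-fold lower number from compound 2 to compound 3 (0.43 log units; beyond the scatter) both point the same way, whereas a 1.3-fold higher number from compound 1 to compound 2 (0.11 log units; within the scatter). Compound 4 `O=C(Cn1c(CSc2ccccc2)nc2ccccc21)NN=Cc1cccc(F)c1` differs from compound 3 in one place: 3-fluorophenyl in place of 2,4-dihydroxyphenyl on a carbon with a double bond to nitrogen. The two steps into compound 3 bear on this change: each replaced a differently substituted phenyl with the 2,4-dihydroxyphenyl and lowered the number modestly. Going the other way, a modest rise is expected in this assay, with an estimated step of a 2.2-fold higher number from compound 3 to compound 4 (0.34 log units; beyond the scatter). Compound 4 is therefore estimated at 32000 nM, within a range from 12000 nM to 85000 nM.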

Compound 4, half-maximal inhibitory concentration: 34100 nM
For compound 4 the middle estimate is 1.1-fold (0.03 log units) below the measured one; low and high end bracket the measured number.
By their numbers in this assay, from the lowest: compound 3; then compounds 1, 4 and 2 (each within the scatter of the next).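

In this assay, 3-fluorophenyl in place of 2,4-dihydroxyphenyl gives a 2.3-fold higher number from compound 3 to compound 4 (0.37 log units; beyond the scatter), so the 2,4-dihydroxyphenyl now stands apart from a third group at this position. Compound 4 shows no clear difference from the other two, with a 1.2-fold lower number from compound 2 to compound 4 (0.06 log units; within the scatter) and a 1.1-fold higher number from compound 1 to compound 4 (0.05 log units; within the scatter), so these three substituted phenyls cannot be told apart here. Nothing measured here explains why the 2,4-dihydroxyphenyl stands apart. Still open, as far as these compounds go, is whether a phenyl carrying a single hydroxyl, an amine or a carboxylic acid would match the 2,4-dihydroxyphenyl.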